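Para substituent swap on the terminal anilide

The source may hold more compounds than are shown below. What is called first, only, known or untested is meant among the compounds shown, and "the series" means these compounds.

The series shares one core, as in compound 1 `CN(C)C(=O)c1cc2cnc(Nc3ccc(NC(=O)C4(C(=O)Nc5ccccc5)CC4)cc3)nc2n1C1CCCC1`, compound 2 `CN(C)C(=O)c1cc2cnc(Nc3ccc(NC(=O)C4(C(=O)Nc5ccccc5F)CC4)cc3)nc2n1C1CCCC1` and compound 3 `COC(=O)c1ccc(NC(=O)C2(C(=O)Nc3ccc(Nc4ncc5cc(C(=O)N(C)C)n(C6CCCC6)c5n4)cc3)CC2)cc1`. In a functional assay on A549 cells (Homo sapiens) for inhibition, read by CCK-8 assay, with a stated time of 72 h, tested at 1 uM (on this read-out higher numbers stand for more inhibition of growth at the one concentration tested and lower numbers for less inhibition of growth), compound 1 gives 75%, compound 2 gives 79.1% and compound 3 gives 77.1%; compound 3 thus lies within the scatter of both neighbours, with a number 2.1 percentage points higher from compound 1 to compound 3 (within the scatter) and a number 2 percentage points lower from compound 2 to compound 3 (within the scatter). Compound 4 `CN(C)C(=O)c1cc2cnc(Nc3ccc(NC(=O)C4(C(=O)Nc5ccc(C(F)(F)F)cc5)CC4)cc3)nc2n1C1CCCC1` carries trifluoromethyl in place of methoxycarbonyl on an aromatic carbon. Going by the values given here, no measured step touches trifluoromethyl; the two steps at this position or on this anilide stayed within scatter, and a number 4.1 percentage points higher from compound 1 to compound 2 (within the scatter) did likewise. No step beyond the scatter is therefore expected in this assay, with a number 1.1 percentage points lower from compound 3 to compound 4 (within the scatter) as the expected change. Compound 4 is estimated at 76%, expected between 62% and 88%.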

Compound 4, percent growth inhibition at one concentration: -25.3%
Estimate against measurement, compound 4: 101.3 percentage points above, and the stated range ends above it.
By their numbers in this assay, from the lowest: compound 4; then compounds 1, 3 and 2 (each within the scatter of the next).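

This position on the terminal anilide does not accept every substituent in this assay: trifluoromethyl departs sharply from methoxycarbonyl (a number 102.4 percentage points lower from compound 3 to compound 4 (beyond the scatter)) and from hydrogen (a number 100.3 percentage points lower from compound 1 to compound 4 (beyond the scatter)). The 2-fluorophenyl anilide gives a comparably large gap (a number 104.4 percentage points lower from compound 2 to compound 4 (beyond the scatter)), so the earlier within-scatter steps did not predict this change. Nothing available bears on why this swap has such an effect.

Going by these compounds, whether the drop is confined to trifluoromethyl or extends to a nitrile, a chlorine atom, a methyl or a carboxylic acid at this position stays open. On these data alone, how compound 4 behaves at other concentrations also stays open.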